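The source may hold more compounds than are shown below. What is called first, only, known or untested is meant among the compounds shown, and "the series" means these compounds.

Series notes. Compound 1 `COc1cc(N)c(Cl)cc1NC(=O)C1CCN(Cc2ccccc2)CC1` carries a benzyl on the ring amine nitrogen of the shared core. Within the data shown here, in a functional assay on the whole organism for antagonist activity, with Mus musculus as the target (on this read-out lower numbers stand for an effect already at smaller amounts and higher numbers for an effect only at larger amounts of compound), compound 1 gives 0.5 mg/kg, the only number recorded in the set. Compound 2 `CCC(CC)CN1CCC(C(=O)Nc2cc(Cl)c(N)cc2OC)CC1` reaches only > 10 mg/kg, a limit (the limit of > 10 mg/kg in this assay, at which 1 of the 3 values shown sits). Compound 3 `COc1cc(N)c(Cl)cc1NC(=O)C1CCN(Cc2ccc(C)c(C)c2)CC1` reaches only > 8 mg/kg, likewise a limit (the limit of > 8 mg/kg in this assay, at which 1 of the 3 values shown sits). The step of an at least 20-fold higher number from compound 1 to compound 2 (1.30 log units; beyond the scatter) and the step of an at least 16-fold higher number from compound 1 to compound 3 (1.20 log units; beyond the scatter) are both large losses from the benzyl parent. Between the two limits the step that the two limits leave unreadable from compound 2 to compound 3. Compound 4 `COc1cc(N)c(Cl)cc1NC(=O)C1CCN(Cc2cccc(Cl)c2)CC1` differs from compound 1 by chloro in place of hydrogen on an aromatic carbon. Among the measured compounds shown here, the closest precedent is the step to compound 3, which also substitutes the phenyl of the benzyl group and cost an at least 16-fold higher number from compound 1 to compound 3 (1.20 log units; beyond the scatter); a single chloro is a smaller change than 3,4-dimethylphenyl in place of phenyl. For the measured compounds named here, a loss beyond the scatter, but smaller than the one to compound 3, is therefore expected for compound 4, as the step of a 4.0-fold higher number from compound 1 to compound 4 (0.60 log units; beyond the scatter). Compound 4 is estimated at 2 mg/kg, in the range 0.5 mg/kg to 10 mg/kg, with a fair chance that this assay again returns only a limit.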

Compound 4, dose for half-maximal effect: > 4 mg/kg
Compound 4 was reported as a limit; the forecaster's own chance of this, stated with the estimate: 30%; middle value at least 2.0-fold (0.30 log units) from the limit.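

Going from benzyl to 3-chlorobenzyl in this assay gives an at least 8.0-fold higher number from compound 1 to compound 4 (0.90 log units; beyond the scatter), so a change of 1 heavy atom on the phenyl ring is already enough for a loss beyond the scatter. Among these compounds, compound 3 left open whether such a loss needs a group as large as 3,4-dimethylphenyl; with compound 4, a lone chloro also goes with a loss, and the unsubstituted benzyl of compound 1 remains the only member with a number. The value of compound 4 is a limit: the limit of > 4 mg/kg in this assay, at which 1 of the 4 values shown sits.

The steps among compound 2, compound 3 and compound 4 cannot be read, so the three limits give no order among these compounds. On these data alone, whether any group on this phenyl ring costs as much remains open, since a fluoro, a methoxy or a hydroxyl at the same place could still separate chloro from the rest.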